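Swapping Butyl for Ethoxy on a Nitroimidazole Chain

This account rests on a few compounds, and the source may have more. Where it says the series, first, only, none or still open, it means among the compounds named here.

Measured in a functional assay on A549 cells (Homo sapiens) for inhibition, read by sulforhodamine B assay, with a stated time of 72 h; a higher number here means a weaker inhibitor, a lower number a stronger inhibitor:
compound 1 `COc1cc2c(Nc3ccc(OCc4cccc(F)c4)c(Cl)c3)ncnc2cc1OCCCCCn1ccnc1[N+](=O)[O-]`: 19900 nM
compound 2 `COc1cc2c(Nc3ccc(OCc4cccc(F)c4)c(Cl)c3)ncnc2cc1OCCCCCCn1ccnc1[N+](=O)[O-]`: > 50000 nM (a limit of the assay)

Compound 2 gives > 50000 nM, which is a limit and not a number. This places it at the limit of > 50000 nM in this assay, at which 1 of the 2 values shown sits.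

Compound 3 `COc1cc2c(Nc3ccc(OCc4cccc(F)c4)c(Cl)c3)ncnc2cc1OCCOCCn1ccnc1[N+](=O)[O-]` has not yet been measured. Its structural change is 2-(2-nitro-1H-imidazol-1-yl)ethoxy in place of 4-(2-nitro-1H-imidazol-1-yl)butyl on a saturated chain carbon, two bonds along the chain from an oxygen on an aromatic ring.

Among the compounds with values here, only one measured step bears on this change, and it does so indirectly. That step is an at least 2.5-fold higher number from compound 1 to compound 2 (0.40 log units; beyond the scatter), with (2-nitro-1H-imidazol-1-yl)methyl in place of 2-nitro-1H-imidazol-1-yl on a saturated chain carbon, five bonds along the chain from an oxygen on an aromatic ring. As far as these compounds go, it is a modest step, and its true size is unknown. A modest move towards a lower number is therefore expected in this assay, though the reading could also remain at the limit.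

The estimated step is an at least 1.7-fold lower number from compound 2 to compound 3 (0.25 log units; that floor lies within the scatter). For compound 3 the expected value is 28000 nM, with an estimated range of 9000 nM to 60000 nM.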

Compound 3, half-maximal inhibitory concentration: 5060 nM
Beside the measured number, compound 3's estimate is 5.5-fold (0.74 log units) above it; the whole stated range lies above it.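

In this assay, putting 2-(2-nitro-1H-imidazol-1-yl)ethoxy in place of 4-(2-nitro-1H-imidazol-1-yl)butyl gives an at least 9.8-fold lower number from compound 2 to compound 3 (0.99 log units; beyond the scatter) and brings the reading off the limit held by compound 2. The size of that step is only a floor, since the value of compound 2 is a limit and not a number: the limit of > 50000 nM in this assay, at which 1 of the 3 values shown sits. The second comparison needs no limit: 2-(2-nitro-1H-imidazol-1-yl)ethoxy in place of 3-(2-nitro-1H-imidazol-1-yl)propyl, on a saturated chain carbon, two bonds along the chain from an oxygen on an aromatic ring, gives a 3.9-fold lower number from compound 1 to compound 3 (0.59 log units; beyond the scatter), so among these three compounds the ethoxy chain of compound 3 reads lower than both all-carbon chains.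

Nothing measured here accounts for why the ethoxy chain reads lower than the butyl and propyl chains. As far as these compounds go, it also remains open how an amine in the same chain, or a shorter chain carrying the same 2-nitro-1H-imidazol-1-yl group, would read at this place in this assay.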